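Extending the amide cap of a weak HDAC6 inhibitor

The source may report more compounds than this note shows. Statements on the series, on what has been measured and on what is new or still open speak of the compounds shown alone.

Of the compounds shown here, two built on one shared core have been measured so far. Compound 1 `C=CCCC(=O)NCCCN1CCc2nc(C(=O)NO)sc2C1` gives 58700 nM in an in vitro assay on cells for inhibition of protein deacetylase HDAC6 (Homo sapiens), read by fluorescence, with a stated time of 3 h; on this read-out lower numbers stand for stronger inhibition and higher numbers for weaker inhibition. Compound 2 `C=CCCC(=O)NCCCCN1CCc2nc(C(=O)NO)sc2C1`, which differs only in the length of the chain between the amide and the ring amine, gives 24800 nM in this assay. Within the data shown here, that single step, a 2.4-fold lower number from compound 1 to compound 2 (0.37 log units; beyond the scatter), is the only comparison available, and on it compound 2 stands as the lower of the two numbers, with compound 1 the nearest measured neighbour.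

Compound 3 `COc1ccc(/C=C/C(=O)NCCCCN2CCc3nc(C(=O)NO)sc3C2)cc1` keeps the longer chain of compound 2 and changes the group on the other side of the amide: 2-(4-methoxyphenyl)ethenyl in place of but-3-en-1-yl on a carbonyl carbon. Among the measured compounds shown here, no measured step touches this part of the molecule; the one known step concerned the chain, not the cap on the carbonyl carbon, so it gives no direct guide to the size or direction of the change here. The expectation is therefore uncertain, and the step of a 3.5-fold lower number from compound 2 to compound 3 (0.55 log units; beyond the scatter) is an estimate rather than a projection from a measured trend. In this assay compound 3 is expected to give about 7000 nM, most likely somewhere between 1000 nM and 40000 nM.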

Compound 3, half-maximal inhibitory concentration: 9550 nM
Compound 3: the middle estimate sits 1.4-fold (0.13 log units) below what was measured; the measured number falls inside the stated range.
By their numbers in this assay, from the lowest: compound 3; then compound 2; then compound 1.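

In this assay the group on this carbonyl carbon turns out to matter: 2-(4-methoxyphenyl)ethenyl in place of but-3-en-1-yl gives a 2.6-fold lower number from compound 2 to compound 3 (0.41 log units; beyond the scatter) on top of the modest step already seen at the chain, so two separate parts of the molecule now respond. The change is a bundle, though, as the entering group brings one six-membered aromatic ring of carbon only and 1 hydrogen-bond acceptor, while both groups carry 1 double bond outside aromatic rings, and a single step cannot show which of these features counts. Nothing available here explains why the number falls.

A plain phenyl on the same ethenyl unit would test the part played by the methoxy group, and a saturated ethyl unit carrying the 4-methoxyphenyl would test the part played by the double bond. From the compounds shown here alone, whether the chain and cap effects add up remains open too, and the 2-(4-methoxyphenyl)ethenyl group on the shorter chain of compound 1, or on a longer chain, would address this.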